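A few compounds are considered here, and "the series" means these few. Any claim that something is new, unique, unknown or untested is made for them only; others in the source may bear on it.

Measured so far in an ADME assay on MRC5 cells (Homo sapiens) for cytotoxicity, read by fluorescence and resazurin assay, with a stated time of 3 days (on this read-out higher numbers stand for an effect only at larger amounts of compound and lower numbers for an effect already at smaller amounts), are these compounds:
compound 1 `COC1(c2nc3ccccc3s2)C=CC(=O)C=C1` with 1100 nM
compound 2 `O=C1C=CC(O)(c2cc3ccc(F)cc3n2S(=O)(=O)c2ccccc2)C=C1` with 170 nM
compound 3 `COC(=O)CCc1ccc(S(=O)(=O)n2c(C3(O)C=CC(=O)C=C3)cc3ccccc32)cc1` with 280 nM

Compound 3 (280 nM) stands within the scatter of compound 2 (170 nM), while compound 1 (1100 nM) reads higher than compound 3, beyond the scatter. Compound 4 `CN1CCN(CCCc2ccc(S(=O)(=O)n3c(C4(O)C=CC(=O)C=C4)cc4ccccc43)cc2)CC1`, not yet measured, carries (4-methylpiperazin-1-yl)methyl in place of methoxycarbonyl on a saturated chain carbon, two bonds along the chain from an aromatic carbon. Among the compounds with values here, no measured pair shows what a single change does in this assay here, so no step beyond the scatter is expected. The expected step (a 1.1-fold lower number from compound 3 to compound 4 (0.05 log units; within the scatter)) is small and uncertain. For compound 4 the estimate is 250 nM (expected range 90 nM to 700 nM).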

Compound 4, half-maximal effective concentration: 50 nM
Beside the measured number, compound 4's estimate is 5.0-fold (0.70 log units) above it; the whole stated range lies above it.
By their numbers in this assay, from the lowest: compound 4; then compounds 2 and 3 (each within the scatter of the next); then compound 1.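

In this assay the exchange of methoxycarbonyl for (4-methylpiperazin-1-yl)methyl gives the first single-change comparison, a 5.6-fold lower number from compound 3 to compound 4 (0.75 log units; beyond the scatter). It shows that a change on a saturated chain carbon, two bonds along the chain from an aromatic carbon, can move the number beyond the scatter, here towards an effect at smaller amounts of compound. No evidence at hand accounts for this step.

From the compounds shown here alone, whether a carboxylic acid, an open-chain dimethylamino group or a morpholine ring would do the same remains open. So does whether a shorter or longer chain would keep the step.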